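Swapping a trifluoromethylphenyl arm for a thiophene ring

A few compounds are considered here, and "the series" means these few. Any claim that something is new, unique, unknown or untested is made for them only; others in the source may bear on it.

Compound 1 `Oc1ccc(CN(Cc2cccc(C(F)(F)F)c2)Cc2ccc(O)c3ncccc23)c2cccnc12` gives 168 nM in a functional assay on HT-22 cells (Mus musculus), read by MTT assay, with a stated time of 24 h; a higher number here means that more compound is needed for the effect, a lower number that less compound is needed. Going by the values given here, compound 2 `Oc1ccc(CN(Cc2ccc(C(F)(F)F)cc2)Cc2ccc(O)c3ncccc23)c2cccnc12` gives 621 nM, the higher of the two numbers; the only measured step, a 3.7-fold higher number from compound 1 to compound 2 (0.57 log units; beyond the scatter), moves the trifluoromethyl group within the same ring. Compound 3 `Oc1ccc(CN(Cc2cccs2)Cc2ccc(O)c3ncccc23)c2cccnc12` goes further: thiophen-2-yl in place of 4-(trifluoromethyl)phenyl on a saturated chain carbon bound to an amine nitrogen. Among the compounds with values here, no measured step swaps one ring type for another, so that step cannot be sized from data; a change somewhat larger than the scatter, in either direction, seems plausible. Compound 3 is therefore estimated at 400 nM, within 120 nM to 1500 nM, corresponding to an expected 1.6-fold lower number from compound 2 to compound 3 (0.19 log units; within the scatter).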

Compound 3, half-maximal effective concentration: 383 nM
Estimate against measurement, compound 3: 1.0-fold (0.02 log units) above; measured number inside the range.
By their numbers in this assay, from the lowest: compound 1; then compounds 3 and 2 (each within the scatter of the next).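

In this assay the arm on a saturated chain carbon bound to an amine nitrogen can change ring type, not only the place of its trifluoromethyl group: a 1.6-fold lower number from compound 2 to compound 3 (0.21 log units; within the scatter) shows that thiophen-2-yl and 4-(trifluoromethyl)phenyl cannot be told apart here. The same swap starting from the other arm gives a 2.3-fold higher number from compound 1 to compound 3 (0.36 log units; beyond the scatter) and leaves compound 1 with the lowest number of the three. No evidence on the cause of these differences is available.

Compound 3 loses the trifluoromethyl group and changes the ring at once. A plain phenyl or a furan-2-yl arm would be needed to separate those two changes.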